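Sulfonamide Series: Hydroxyphenyl in Place of Methylphenyl

The source may hold more compounds than are shown below. What is called first, only, known or untested is meant among the compounds shown, and "the series" means these compounds.

Compound 1 `Cc1ccc(S(=O)(=O)Nc2ccc(-c3nc4ccccc4o3)cc2)cc1` has been tested in an assay on isolated protein for inhibition of malate dehydrogenase, mitochondrial (Sus scrofa), with stated times of 45 min and 30 min; on this read-out lower numbers stand for stronger inhibition and higher numbers for weaker inhibition. In this assay compound 1 reaches only a limit, > 63000 nM. Compound 2 `O=S(=O)(Nc1ccc(-c2nc3ccccc3o2)cc1)c1ccc(F)c(C(F)(F)F)c1` likewise reaches only a limit in this assay, > 63000 nM. Compound 3 `O=S(=O)(Nc1ccc2oc(-c3ccccc3)nc2c1)c1ccc(F)c(C(F)(F)F)c1` also stops at a limit in this assay, > 63000 nM. Within the data shown here, compound 1 therefore stands nowhere on a scale of numbers: all three values sit at the limit of > 63000 nM in this assay, at which 3 of the 3 values shown sit, and no compound can be placed above or below another.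

Compound 4 `O=S(=O)(Nc1ccc(-c2nc3ccccc3o2)cc1)c1ccccc1O` has not yet been measured in this assay. It differs from compound 1 in one place: 2-hydroxyphenyl in place of 4-methylphenyl on a sulfonyl sulfur. Among the measured compounds shown here, no step between two measured compounds is available, so the size of this change cannot be read from the data. With every measured value at the limit, the expected step in this assay is a number no higher from compound 1 to compound 4 (the limit leaves the size open), none beyond the scatter. Compound 4 is accordingly estimated at 63000 nM, with a range from 15000 nM to 250000 nM. A limit rather than a number is the more likely outcome for compound 4.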

Compound 4, half-maximal inhibitory concentration: > 63000 nM
Compound 4: only a limit was reported (the forecaster's own chance of this, stated with the estimate: 70%); the middle value sits exactly at the limit.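

In this assay compound 4 stops at a limit, > 63000 nM. Among these compounds, compound 1 also stands at a limit, so no step between compound 1 and compound 4 can be read. Whether 2-hydroxyphenyl in place of 4-methylphenyl on a sulfonyl sulfur alters inhibition at all stays open, as does any ordering of the compounds shown: the limit of > 63000 nM in this assay, at which 4 of the 4 values shown sit.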